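Ester in place of benzoyl on an aminothiophene core

The compounds below may be only part of what the source reports. "The series", "measured", "known", "first", "only" and "open" are said of these compounds alone.

The two measured compounds share an aminothiophene core. Compound 1 `CCOC(=O)c1c(-c2cccc(C(F)(F)F)c2)csc1N` gives 9.4 uM in a functional assay on CHO-K1 cells for agonist activity at adenosine receptor A1 (Homo sapiens), read by GTPgammaS binding (a lower number here means that less compound is needed, a higher number that more compound is needed for the effect), while compound 2 `Nc1sc(-c2ccccc2)c(-c2cccc(C(F)(F)F)c2)c1C(=O)c1ccccc1` gives 2.3 uM, the lower of the two values and beyond the usual scatter of compound 1. Compound 3 `CCOC(=O)c1c(N)sc(-c2ccccc2)c1-c1cccc(C(F)(F)F)c1` differs from compound 2 by ethoxy in place of phenyl on a carbonyl carbon. Because compound 1, which also carries the ethoxycarbonyl group, gives 9.4 uM, a modest loss is expected, and the step of a 2.4-fold higher number from compound 2 to compound 3 (0.38 log units; beyond the scatter) is expected to fall beyond the scatter. Compound 3 is therefore estimated at 5.5 uM, within 1.8 uM to 17 uM.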

Compound 3, concentration for half-maximal effect: > 10 uM
Compound 3 was reported as a limit (the forecaster's own chance of this, stated with the estimate: 10%); middle value at least 1.8-fold (0.25 log units) away from the limit.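

Ethoxy in place of phenyl on a carbonyl carbon, the change from benzoyl to ethoxycarbonyl, is an at least modest step, with an at least 4.3-fold higher number from compound 2 to compound 3 (0.63 log units; beyond the scatter). The value of compound 3 is a limit, not a number: the limit of > 10 uM in this assay, at which 1 of the 3 values shown sits. Phenyl in place of hydrogen on an aromatic carbon gives an at least 1.0-fold higher number from compound 1 to compound 3 (0.02 log units; that floor lies within the scatter), and this step cannot be read, its floor lying within the scatter.

Going by these compounds, how a methyl group or an amine on this carbonyl carbon would compare with phenyl and ethoxy remains open. So does the effect of phenyl in place of hydrogen on the shared core.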